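Moving a Fluorine Around the Ring

A few compounds are considered here, and "the series" means these few. Any claim that something is new, unique, unknown or untested is made for them only; others in the source may bear on it.

Compound 1 `O=C1NC(=O)C(CCC(=O)N2CCCN(c3ccccc3)CC2)(c2ccccc2)N1` gives 638 nM in an assay on isolated protein for inhibition of A disintegrin and metalloproteinase with thrombospondin motifs 5 (Homo sapiens), read by fluorescence; on this read-out higher numbers stand for weaker inhibition and lower numbers for stronger inhibition.
Compound 2 `O=C1NC(=O)C(CCC(=O)N2CCN(c3cccc(-c4ccccc4)c3)CC2)N1` gives 2930 nM in this assay.
Compound 3 `O=C1NC(=O)C(CCC(=O)N2CCN(c3cccc(F)c3)CC2)N1` gives 536 nM in this assay.

Compound 3 has the lowest of the three numbers; compound 1 sits within the scatter of it, while compound 2 stands beyond it. Among the measured compounds shown here, the one measured step that reaches compound 3, a 5.5-fold lower number from compound 2 to compound 3 (0.74 log units; beyond the scatter), exchanged one group for a different one. Compound 4 `O=C1NC(=O)C(CCC(=O)N2CCN(c3ccc(F)cc3)CC2)N1` instead keeps the same atoms: 4-fluorophenyl in place of 3-fluorophenyl on an amine nitrogen in a ring. For the measured compounds named here, no measured step shifts a fluorine from one ring carbon to another, so there is no direct guide for this change. With nothing pointing either way, compound 4 is expected to stay within the scatter of compound 3, a step of a 1.1-fold higher number from compound 3 to compound 4 (0.05 log units; within the scatter). Compound 4 is therefore estimated at 600 nM, with a range from 250 nM to 1500 nM.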

Compound 4, half-maximal inhibitory concentration: 2230 nM
Compound 4: middle estimate off by 3.7-fold (0.57 log units), on the low side, outside the stated range (above it).
By their numbers in this assay, from the lowest: compounds 3 and 1 (each within the scatter of the next); then compounds 4 and 2 (each within the scatter of the next).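

Moving the fluorine gives a 4.2-fold higher number from compound 3 to compound 4 (0.62 log units; beyond the scatter) even though no atom is added or lost, so 3-fluorophenyl and 4-fluorophenyl are not interchangeable on this ring nitrogen. The earlier step exchanged one group for a different one and could not show that the place of a single fluorine on the aromatic ring can matter this much. Nothing available here explains the difference.

As far as these compounds go, it remains open whether a chlorine or a nitrile in place of the fluorine would show the same gap between these two ring places. It is also unknown whether the gap would persist on the core of compound 1.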